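The compounds below may be only part of what the source reports. "The series", "measured", "known", "first", "only" and "open" are said of these compounds alone.

In a functional assay on HeLa cells (Homo sapiens) for antiproliferative activity, read by sulforhodamine B assay, with a stated time of 48 h (a lower number here means a stronger inhibitor, a higher number a weaker inhibitor), compound 1 (`COc1ccc2nc(-c3ccc(N/C=C\C(=O)c4ccc(OC)c(O)c4)c(C)c3)sc2c1`) gives 12000 nM. Compound 2 (`COc1cc(OC)c2sc(-c3ccc(N/C=C\C(=O)c4ccc(OC)c(O)c4)cc3)nc2c1`) gives 12100 nM, a value practically the same as that of compound 1, and compound 3 (`COc1ccc2nc(-c3ccc(N/C=C\C(=O)c4ccc(OC)c(O)c4)cc3)sc2c1`) gives 6900 nM. Compound 1 therefore has one close neighbour on the numbers and one further off, though that further gap is still small.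

The next structure is compound 4 (`COc1ccc2nc(-c3ccc(N/C=C\C(=O)c4ccc(OC)c([N+](=O)[O-])c4)c(C)c3)sc2c1`), which keeps the core of compound 1 and changes only the aryl ketone end: nitro in place of hydroxy on an aromatic carbon. In words, this is nitro in place of hydroxy on an aromatic carbon, taking 3-hydroxy-4-methoxyphenyl to 4-methoxy-3-nitrophenyl.

Among the compounds with values here, the only measured step that bears on this is a 1.7-fold lower number from compound 1 to compound 3 (0.24 log units; within the scatter), hydrogen in place of methyl on an aromatic carbon. It lies at a different place in the molecule, so it speaks only to how little the numbers have moved in this small set. All three measured compounds carry the hydroxy group, so the data hold no direct test of replacing it, and no clear direction can be drawn.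

The expected step is a 1.2-fold higher number from compound 1 to compound 4 (0.07 log units; within the scatter), which means no change beyond the scatter is anticipated. For compound 4 the estimate is 14000 nM, with an expected range of 4500 nM to 45000 nM.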

Compound 4, half-maximal inhibitory concentration: 17600 nM
Compound 4: middle estimate off by 1.3-fold (0.10 log units), on the low side, and the stated range covers the measured number.
By their numbers in this assay, from the lowest: compounds 3, 1, 2 and 4 (each within the scatter of the next, the first and the last beyond it).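

Within the data shown here, this is the first change at the aromatic carbon that carries the hydroxy group of the 3-hydroxy-4-methoxyphenyl end, ortho to a methoxy group, a position held constant across the three earlier compounds. In this assay, the step shows a 1.5-fold higher number from compound 1 to compound 4 (0.17 log units; within the scatter), so on the core of compound 1, exchanging hydroxy, with 1 hydrogen-bond donor, for nitro, with 0 hydrogen-bond donors and 3 heavy atoms, gives no change beyond the scatter, and this single pair shows that the hydroxy group is not needed to keep the number at this level. No available evidence accounts for this outcome.

The compounds shown leave open whether an amine or a carboxylic acid on this aromatic carbon would also stay within the scatter, and whether nitro in place of hydroxy would give the same reading with the groups carried by compound 2 or compound 3. From the compounds shown here alone, the methoxy group stands in all four compounds, so the effect of an ethoxy group in its place also remains open.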